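Removing the chain methyl from compound 2

A few compounds are considered here, and "the series" means these few. Any claim that something is new, unique, unknown or untested is made for them only; others in the source may bear on it.

Measured so far in an ADME assay for solubility, in simulated intestinal fluid; a lower number here means a less soluble compound, a higher number a more soluble compound
- compound 1 `O=C(Nc1cccn(Cc2ccccc2)c1=O)c1ccc2c(c1)B(O)OC2` gives 3 ug/mL
- compound 2 `CC(C(=O)NS(=O)(=O)C1CC1)c1ccc2c(c1)B(O)OC2` gives > 1000 ug/mL (a limit)
- compound 3 `O=C(O)CCc1ccc2c(c1)B(O)OC2` gives > 1000 ug/mL (a limit)

Compound 2 reads > 1000 ug/mL in this assay as a limit and not as a number. It stands at that limit with one other compound (the limit of > 1000 ug/mL in this assay, at which 2 of the 3 values shown sit). Compound 4 `O=C(Cc1ccc2c(c1)B(O)OC2)NS(=O)(=O)C1CC1` has hydrogen in place of methyl on a saturated chain carbon bound to an aromatic carbon and a carbonyl carbon. Among the compounds with values here, no measured step covers this change, and none beyond the scatter is expected in this assay. Compound 3, which has no such methyl, also reads > 1000 ug/mL as a limit. The estimated step is a number no higher from compound 2 to compound 4 (the limit leaves the size open) and has no expected direction. For compound 4 the expected value is 1000 ug/mL (range 400 ug/mL to 2000 ug/mL), quite possibly reported only as a limit.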

Compound 4, solubility: 700 ug/mL
The estimate for compound 4 lay 1.4-fold (0.15 log units) above the measured number; the range from low to high includes it.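

In this assay compound 4 gives 700 ug/mL, a number and not a limit, so this series now has a readable value with hydrogen on the saturated chain carbon. The change to hydrogen in place of methyl is read as an at least 1.4-fold lower number from compound 2 to compound 4 (0.15 log units; that floor lies within the scatter), which does not show that the methyl matters. Compound 2 is a limit, so the full size of the step cannot be read: the limit of > 1000 ug/mL in this assay, at which 2 of the 4 values shown sit.

Going by these compounds, what an ethyl or a hydroxyl on this saturated chain carbon would give in this assay remains open.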